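The source may hold more compounds than are shown below. What is called first, only, known or untested is meant among the compounds shown, and "the series" means these compounds.

Compound 2, with structure `O=C(O)CCc1ccc(NC(=O)c2nnc(COc3cccc(C(F)(F)F)c3)s2)cc1`, is one of two compounds in the series measured in a functional assay on CHO cells for agonist activity at Free fatty acid receptor 1 (Homo sapiens), read by FLIPR and calcium flux, tested at 1 uM; a higher number here means that more compound is needed for the effect, a lower number that less compound is needed. In this assay compound 2 gives 3090 nM, the higher of the two numbers. Its neighbour, compound 1 `Cc1ccc(C)c(OCc2nnc(C(=O)Nc3ccc(CCC(=O)O)cc3)s2)c1`, gives 1530 nM in this assay, and the step of a 2.0-fold higher number from compound 1 to compound 2 (0.31 log units; beyond the scatter) is the only one available. Compound 3 `COc1ccc(OCc2nnc(C(=O)Nc3ccc(CCC(=O)O)cc3)s2)cc1` has not yet been measured; it differs from compound 2 in one place: 4-methoxyphenyl in place of 3-(trifluoromethyl)phenyl on an oxygen on a saturated carbon. Going by the values given here, the one measured step shows that exchanging the aryl group on this oxygen shifts the number modestly, so a shift of similar size is expected here, though its direction cannot be read from a single step. Compound 3 is therefore expected to give about 2000 nM in this assay, within a range of 700 nM to 6000 nM, which corresponds to an expected step of a 1.5-fold lower number from compound 2 to compound 3 (0.19 log units; within the scatter).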

Compound 3, half-maximal effective concentration: 2430 nM
Compound 3: the middle estimate sits 1.2-fold (0.08 log units) below what was measured; the measured number falls inside the stated range.
By their numbers in this assay, from the lowest: compounds 1, 3 and 2 (each within the scatter of the next, the first and the last beyond it).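

In this assay, 4-methoxyphenyl on an oxygen on a saturated carbon cannot be told apart from 3-(trifluoromethyl)phenyl, with a 1.3-fold lower number from compound 2 to compound 3 (0.10 log units; within the scatter), or from 2,5-dimethylphenyl, with a 1.6-fold higher number from compound 1 to compound 3 (0.20 log units; within the scatter), since both steps lie within the scatter. The entering group carries 1 hydrogen-bond acceptor where 3-(trifluoromethyl)phenyl carries 0, and this exchange leaves the number within the scatter, so the position tolerates this change of aryl group without a readable shift. No measurement at hand bears on why this is so.

Going by these compounds, the three aryl groups show only a narrow band of numbers, so it remains open whether a cyclohexyl group or an amine at this place would leave that band. On these data alone, how far the number depends on the carboxylic acid chain of the shared core also stays open.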